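Replacing the Cyanoguanidine Group with a Thiourea Group

The source may report more compounds than this note shows. Statements on the series, on what has been measured and on what is new or still open speak of the compounds shown alone.

Compound 3 `C/N=C(/NC#N)N(C)CCCCn1nc(-c2ccccc2)ccc1=O` was tested in a functional assay on the whole organism (stomach) with Rattus norvegicus as the target; a higher number here means that more compound is needed for the effect, a lower number that less compound is needed. Compound 3 reached only a limit of the assay, > 100 mg/kg, so no number is known for it. Compound 1 `C/N=C(/NC#N)NCCCn1nc(-c2ccccc2)ccc1=O` also gave only a limit, > 100 mg/kg. Compound 2 `C/N=C(\S)NCCCCn1nc(-c2ccccc2)ccc1=O` gave a number, 28.9 mg/kg. Compound 4 `C=CCNC(=S)NCCCCn1nc(-c2ccccc2)ccc1=O` has not yet been measured; it differs from compound 3 in one place: a group of 7 heavy atoms (4 carbon, 2 nitrogen, 1 sulfur; no ring) in place of a group of 8 heavy atoms (4 carbon, 4 nitrogen; no ring), on a saturated chain carbon, four bonds along the chain from an aromatic nitrogen. For the measured compounds named here, two measured steps bear on this exchange of a cyanoguanidine-type group for a sulfur-bearing group. In the first, an at least 3.4-fold lower number from compound 1 to compound 2 (0.53 log units; beyond the scatter); in the second, an at least 3.4-fold higher number from compound 2 to compound 3 (0.53 log units; beyond the scatter). Both steps are only bounds because of the limit of > 100 mg/kg in this assay, at which 2 of the 3 values shown sit. Compound 4 carries the sulfur-bearing group like compound 2, so a lower number is expected for compound 4, in a step of an at least 3.3-fold lower number from compound 3 to compound 4 (0.52 log units; beyond the scatter) that is at least modest. The estimate for compound 4 in this assay is 30 mg/kg, within a range from 10 mg/kg to 100 mg/kg.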

Compound 4, dose for half-maximal effect: > 100 mg/kg
Compound 4: only a limit was reported; the forecaster's own chance of this, stated with the estimate: 25%; middle value at least 3.3-fold (0.52 log units) away from the limit.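

Compound 4 gave only a limit of the assay in this assay, so carrying sulfur in place of the cyanoguanidine-type group is not enough on its own. The change on an amine nitrogen, from the smaller group of compound 2 to the larger group of compound 4, gives an at least 3.4-fold higher number from compound 2 to compound 4 (0.53 log units; beyond the scatter), so the group on that nitrogen matters as well as the sulfur. The steps from compound 3 and from compound 1 to compound 4 cannot be read, with limits at both ends: the limit of > 100 mg/kg in this assay, at which 3 of the 4 values shown sit.

On these data alone, it remains open whether an ethyl group on that amine nitrogen would still give a number like that of compound 2. A urea on the same chain, with oxygen in place of the sulfur, would show how much the sulfur itself counts.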